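The source may hold more compounds than are shown below. What is called first, only, known or untested is meant among the compounds shown, and "the series" means these compounds.

Measured compounds in a functional assay on the whole organism for inhibition, with Rattus norvegicus as the target, read by paw edema; a lower number here means that less compound is needed, a higher number that more compound is needed for the effect:

- compound 1 `O=C(O)c1cc(-c2cocn2)ccc1O`: 110 mg/kg
- compound 2 `O=C(O)c1cc(-n2ccnc2)ccc1O`: 75 mg/kg
- compound 3 `O=C(O)c1cc(-c2nccs2)ccc1O`: reported only as a limit, > 250 mg/kg

Compound 1 stands highest of the two numbers given in this assay; its nearest neighbour is compound 2, with a 1.5-fold lower number from compound 1 to compound 2 (0.17 log units; within the scatter). Compound 3 sits at the limit of > 250 mg/kg in this assay, at which 1 of the 3 values shown sits, so it gives no number, only a limit. The two steps leaving compound 1 differ in kind: an at least 2.2-fold higher number from compound 1 to compound 3 (0.35 log units; beyond the scatter) is beyond the scatter, whereas the exchange toward compound 2 stays within it.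

Compound 4 `O=C(O)c1cc(-n2cnnc2)ccc1O` is not yet measured. It differs from compound 1 by 4H-1,2,4-triazol-4-yl in place of 1,3-oxazol-4-yl on an aromatic carbon. Within the data shown here, the steps that bear on this are the exchange of one five-membered heteroaryl for another on the same core: a 1.5-fold lower number from compound 1 to compound 2 (0.17 log units; within the scatter), within the scatter, and an at least 2.2-fold higher number from compound 1 to compound 3 (0.35 log units; beyond the scatter), at least modest and toward a higher number. The entering 4H-1,2,4-triazol-4-yl is closer in character to the 1H-imidazol-1-yl of compound 2 than to the 1,3-thiazol-2-yl of compound 3, so the expectation is a step in this assay of no more than the scatter, in no firm direction, with some risk of a limit as seen for compound 3.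

Compound 4 is therefore expected to give about 95 mg/kg, with a range from 45 mg/kg to 200 mg/kg. The expected step is a 1.2-fold lower number from compound 1 to compound 4 (0.06 log units; within the scatter).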

Compound 4, dose for half-maximal effect: > 250 mg/kg
Compound 4: no number, only a limit; the forecaster's own chance of this, stated with the estimate: 20%; middle value at least 2.6-fold (0.42 log units) from the limit.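

Among these compounds, the exchange at this place, para to a hydroxy group and meta to a carboxy group, is not as forgiving in this assay as the first pair of compounds alone suggested: the 4H-1,2,4-triazol-4-yl gives an at least 2.2-fold higher number from compound 1 to compound 4 (0.35 log units; beyond the scatter), and an at least 3.3-fold higher number from compound 2 to compound 4 (0.52 log units; beyond the scatter). Both steps lie beyond the scatter, so the 1H-imidazol-1-yl of compound 2 is no guide to the 4H-1,2,4-triazol-4-yl, and among the compounds shown only the 1,3-oxazol-4-yl of compound 1 and the 1H-imidazol-1-yl of compound 2 give a number at all. Compound 4 is reported only as a limit, as is compound 3, and the step between them cannot be read: the limit of > 250 mg/kg in this assay, at which 2 of the 4 values shown sit.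

As far as these compounds go, how far compound 4 lies past that limit stays open, and so does any ranking of the 4H-1,2,4-triazol-4-yl against the 1,3-thiazol-2-yl. Also open, from the compounds shown here alone, is whether the heteroaryl ring is needed here at all or only particular hetero atoms within it, a question that a plain phenyl ring or a pyrrol-1-yl at the same place on the shared core would address.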